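The source may hold more compounds than are shown below. What is called first, only, known or untested is meant among the compounds shown, and "the series" means these compounds.

Compound 3 `O=C(CN1CCC(c2cccc[n+]2[O-])CC1)Nc1ccc(F)cc1F` gives 103 nM in a functional assay on HEK293 cells for agonist activity at D(4) dopamine receptor (Homo sapiens), read by FLIPR (a higher number here means that more compound is needed for the effect, a lower number that less compound is needed), the highest of the three numbers, but no further than the scatter from either neighbour: a 1.7-fold higher number from compound 1 to compound 3 (0.22 log units; within the scatter) and a 2.0-fold higher number from compound 2 to compound 3 (0.30 log units; within the scatter). Compound 1 `O=C(CN1CCC(c2cccc[n+]2[O-])CC1)Nc1cccc(Cl)c1` gives 62 nM and compound 2 `Cc1cc(C)cc(NC(=O)CN2CCC(c3cccc[n+]3[O-])CC2)c1` gives 52 nM; the step of a 1.2-fold lower number from compound 1 to compound 2 (0.08 log units; within the scatter) also stays within the scatter. Compound 4 `Cc1cc(F)ccc1NC(=O)CN1CCC(c2cccc[n+]2[O-])CC1` differs from compound 3 by methyl in place of fluoro on an aromatic carbon. Every measured step in this set exchanges the whole aryl group on the amide-type nitrogen, and none leaves the scatter, so a single methyl in place of fluoro on that ring is expected to give no step beyond the scatter either, a 1.3-fold lower number from compound 3 to compound 4 (0.11 log units; within the scatter). Compound 4 is therefore estimated at 80 nM, with a range of 35 nM to 200 nM.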

Compound 4, half-maximal effective concentration: 60 nM
Compound 4: the middle estimate sits 1.3-fold (0.12 log units) above what was measured; the range from low to high includes it.
By their numbers in this assay, from the lowest: compounds 2, 4, 1 and 3 (each within the scatter of the next).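

In this assay, among the compounds shown here, this is the first step confined to a single group on the aryl ring, and methyl in place of fluoro, ortho to a large group, stays within the scatter, with a 1.7-fold lower number from compound 3 to compound 4 (0.23 log units; within the scatter). The 4-fluoro-2-methylphenyl group also stays within the scatter of the other aryl groups, with a 1.2-fold higher number from compound 2 to compound 4 (0.06 log units; within the scatter) and a 1.0-fold lower number from compound 1 to compound 4 (0.01 log units; within the scatter). Nothing at hand explains this result.

The aryl groups shown carry only fluoro, chloro or methyl, so the outcome with an amine or a carboxylic acid at this position remains open. From the compounds shown here alone, a longer chain in place of methyl also remains untested here.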